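A Second Methoxy Group on the Aryl Ring of Compound 2

The compounds below may be only part of what the source reports. "The series", "measured", "known", "first", "only" and "open" are said of these compounds alone.

Compound 1, `O=C(/C=C/c1ccc(Cl)c(Cl)c1)c1ccc(N2C(=O)C=CC2=O)cc1`: in a functional assay on MOLT-4 cells (Homo sapiens) for cytotoxicity (on this read-out lower numbers stand for stronger inhibition and higher numbers for weaker inhibition), compound 1 gives 8800 nM.
Compound 2, `COc1ccc(/C=C/C(=O)c2ccc(N3C(=O)C=CC3=O)cc2)cc1`: in this assay compound 2 gives 7900 nM.

Compound 2 carries the lower of the two numbers, yet the step of a 1.1-fold lower number from compound 1 to compound 2 (0.05 log units; within the scatter) keeps the two compounds within the scatter of each other. Compound 3, `COc1ccc(/C=C/C(=O)c2ccc(N3C(=O)C=CC3=O)cc2)cc1OC`, differs from compound 2 by methoxy in place of hydrogen on an aromatic carbon. Among the measured compounds shown here, the only measured step concerns another part of the structure and was itself small, so no shift beyond the scatter is expected for compound 3, with a 1.1-fold lower number from compound 2 to compound 3 (0.05 log units; within the scatter). Compound 3 is therefore estimated at 7000 nM, in the range 3000 nM to 18000 nM.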

Compound 3, half-maximal inhibitory concentration: 202000 nM
Compound 3: the middle estimate sits 29-fold (1.46 log units) below what was measured; the whole stated range lies below it.
By their numbers in this assay, from the lowest: compounds 2 and 1 (each within the scatter of the next); then compound 3.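

In this assay, methoxy in place of hydrogen on an aromatic carbon, ortho to a methoxy group and meta to a large group, gives a 26-fold higher number from compound 2 to compound 3 (1.41 log units; beyond the scatter) and so weaker inhibition. This carbon of the ring is therefore sensitive to substitution, which the earlier swap of 3,4-dichlorophenyl for 4-methoxyphenyl did not reveal, since a 1.1-fold lower number from compound 1 to compound 2 (0.05 log units; within the scatter) stayed within the scatter. Nothing available explains the weakening. The compounds shown leave open whether the weakening is specific to methoxy or follows any added group on this carbon, as a hydroxyl, a fluorine or an amine there would tell.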